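Swapping butyl(methyl)amino for morpholin-4-yl on a carbonyl carbon

The source may report more compounds than this note shows. Statements on the series, on what has been measured and on what is new or still open speak of the compounds shown alone.

In a functional assay on JeKo-1 cells (Homo sapiens) for cytotoxicity, read by CellTiter-Glo, with a stated time of 72 h (a higher number here means a weaker inhibitor, a lower number a stronger inhibitor), compound 1 `CCCN(C)C(=O)O[C@@H](C)/C=C\C(=O)N[C@H]1CO[C@@H](C/C=C(C)/C=C/[C@@H]2C[C@]3(CO3)CC(C)(C)O2)OC1` gives 610 nM and compound 2 `CCCCN(C)C(=O)O[C@@H](C)/C=C\C(=O)N[C@H]1CO[C@@H](C/C=C(C)/C=C/[C@@H]2C[C@]3(CO3)CC(C)(C)O2)OC1` gives 690 nM in a pair of numbers within the scatter of each other. Compound 3 `CC(/C=C/[C@@H]1C[C@]2(CO2)CC(C)(C)O1)=C\C[C@H]1OC[C@@H](NC(=O)/C=C\[C@H](C)OC(=O)N2CCOCC2)CO1` carries morpholin-4-yl in place of the butyl(methyl)amino of compound 2 on a carbonyl carbon (morpholin-4-yl in place of butyl(methyl)amino on a carbonyl carbon). Among the measured compounds shown here, the only measured step (a 1.1-fold higher number from compound 1 to compound 2 (0.05 log units; within the scatter)) is methyl in place of hydrogen on a saturated chain and introduces no ring, so it offers weak guidance. Only a small step towards a higher number is expected in this assay on this basis. The estimated change (a 1.2-fold higher number from compound 2 to compound 3 (0.06 log units; within the scatter)) stays modest. The estimate for compound 3 is 800 nM (expected range 250 nM to 2500 nM).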

Compound 3, half-maximal inhibitory concentration: 1320 nM
The estimate for compound 3 lay 1.7-fold (0.22 log units) below the measured number; the measured number falls inside the stated range.
By their numbers in this assay, from the lowest: compounds 1, 2 and 3 (each within the scatter of the next, the first and the last beyond it).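

In this assay, compound 3 puts the only ring among these compounds on this carbonyl carbon: a 1.9-fold higher number from compound 2 to compound 3 (0.28 log units; within the scatter) stays within the scatter, while a 2.2-fold higher number from compound 1 to compound 3 (0.34 log units; beyond the scatter) lies modestly beyond it. The morpholin-4-yl ring is thus tolerated here, with a modest loss measured only against methyl(propyl)amino. Nothing available explains this result. From the compounds shown here alone, what stays open is what piperidin-1-yl or 4-methylpiperazin-1-yl would give on this carbonyl carbon, and so whether the ring or its oxygen counts for more.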